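The source may hold more compounds than are shown below. What is called first, only, known or untested is meant among the compounds shown, and "the series" means these compounds.

Measured in a functional assay on Right cardiac atrium for agonist activity at histamine H2 receptor (Cavia porcellus), with a stated time of 30 min, in the presence of a further agent that is not named here; on this read-out lower numbers stand for an effect already at smaller amounts and higher numbers for an effect only at larger amounts of compound:
compound 1 `COc1ccc(C(C)NC(=O)/N=C(\N)NCCCc2sc(N)nc2C)cc1` gives 38 nM
compound 2 `Cc1nc(N)sc1CCCN/C(N)=N/C(=O)NC(C)c1ccccc1F` gives 12.3 nM
compound 3 `Cc1nc(N)sc1CCCN/C(N)=N/C(=O)NC(C)c1ccc(F)cc1` gives 23.4 nM

Among these three numbers compound 3 has the second highest. Its nearest neighbour is compound 1, and a 1.6-fold lower number from compound 1 to compound 3 (0.21 log units; within the scatter) lies within the scatter; a 1.9-fold higher number from compound 2 to compound 3 (0.28 log units; within the scatter) also stays within it, so no order can be read between these compounds.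

Compound 4 `Cc1nc(N)sc1CCCN/C(N)=N/C(=O)NC(C)c1cccc(F)c1` differs from compound 3 in one place: 3-fluorophenyl in place of 4-fluorophenyl on a saturated chain carbon bound to an amide-type nitrogen and a saturated chain carbon. The change keeps the same atoms and only joins them differently. The measured steps that bear on it are those exchanging the phenyl group on the same chain carbon: a 3.1-fold lower number from compound 1 to compound 2 (0.49 log units; beyond the scatter) was modest and beyond the scatter, whereas a 1.9-fold higher number from compound 2 to compound 3 (0.28 log units; within the scatter), which exchanged one fluorophenyl for another, stayed within it. Exchanging one fluorophenyl for another is therefore expected to give a step of no more than the scatter, a 1.3-fold lower number from compound 3 to compound 4 (0.11 log units; within the scatter), with no direction called. Compound 4 is estimated at 18 nM, with a range from 8 nM to 40 nM.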

Compound 4, half-maximal effective concentration: 26.3 nM
Estimate against measurement, compound 4: 1.5-fold (0.16 log units) below, within the range that was stated.
By their numbers in this assay, from the lowest: compounds 2, 3, 4 and 1 (each within the scatter of the next, the first and the last beyond it).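

In this assay, 3-fluorophenyl cannot be told apart from 4-fluorophenyl (a 1.1-fold higher number from compound 3 to compound 4 (0.05 log units; within the scatter)) or from 4-methoxyphenyl (a 1.4-fold lower number from compound 1 to compound 4 (0.16 log units; within the scatter)) on this saturated chain carbon, since both steps stay within the scatter. Against 2-fluorophenyl, however, the same group gives a modest step beyond the scatter (a 2.1-fold higher number from compound 2 to compound 4 (0.33 log units; beyond the scatter)), so moving the fluorine around the ring can register here, although the step between 2-fluorophenyl and 4-fluorophenyl stayed within the scatter. Nothing available explains this small separation.

The compounds shown leave open whether an unsubstituted phenyl, a 2-chlorophenyl or a pyridyl ring at this place would fall within the same narrow band of numbers. They also leave open whether a longer chain in place of the methyl on this carbon would be tolerated.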